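A few compounds are considered here, and "the series" means these few. Any claim that something is new, unique, unknown or untested is made for them only; others in the source may bear on it.

Three measured compounds share one core and differ only in what hangs from the oxygen on an aromatic ring. In a functional assay (Homo sapiens) for antiproliferative activity, read by resazurin assay, with a stated time of 48 h, tested at 10 uM (a higher number here means a stronger effect of the compound at the concentration tested, a lower number a weaker effect), compound 1 `COc1cc(OC)c2c(=O)cc(-c3ccc(OCCN4CCCC4=O)cc3)oc2c1` gives 14%. Compound 2 `COc1cc(OC)c2c(=O)cc(-c3ccc(OC4CCNCC4)cc3)oc2c1` gives 21% in this assay, and compound 3 `COc1cc(OC)c2c(=O)cc(-c3ccc(OCC(O)CO)cc3)oc2c1` gives 11% in this assay. Compound 3 has the lowest of the three numbers, but neither gap reaches beyond the scatter: a number 3 percentage points lower from compound 1 to compound 3 (within the scatter) and a number 10 percentage points lower from compound 2 to compound 3 (within the scatter). The remaining pair is likewise flat, a number 7 percentage points higher from compound 1 to compound 2 (within the scatter).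

Compound 4 `COc1cc(OC)c2c(=O)cc(-c3ccc(Br)cc3)oc2c1` takes the step (bromo in place of 2,3-dihydroxypropoxy on an aromatic carbon). The whole oxygen-bearing chain is gone and a single bromine stands on the aromatic carbon. Among the measured compounds shown here, no measured step removes the oxygen or brings in a halogen, so none bears on this change directly; the three steps that do bear on it swap groups at the same position and all stay within the scatter. Nothing in the series therefore points to a move beyond the scatter in this assay, and a step of a number 4 percentage points higher from compound 3 to compound 4 (within the scatter) is expected. For compound 4 the estimate in this assay is 15%, with a range from 0% to 35%.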

Compound 4, a percentage reported as inhibition, at one concentration (the size of the read-out at that concentration, not a potency): 10%
Beside the measured number, compound 4's estimate is 5 percentage points above it; low and high end bracket the measured number.
By their numbers in this assay, from the lowest: compounds 4, 3, 1 and 2 (each within the scatter of the next, the first and the last beyond it).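

Notes on the aromatic carbon para to a large group: in this assay, the oxygen-linked chain can go entirely without a shift beyond the scatter against two of the earlier compounds, with a number 1 percentage points lower from compound 3 to compound 4 (within the scatter) for bromo in place of 2,3-dihydroxypropoxy and a number 4 percentage points lower from compound 1 to compound 4 (within the scatter) for bromo in place of 2-(2-oxopyrrolidin-1-yl)ethoxy. Among the compounds shown here, the series now holds its first step beyond the scatter, a number 11 percentage points lower from compound 2 to compound 4 (beyond the scatter), a modest one for bromo in place of (piperidin-4-yl)oxy, so only this pair separates, while compound 2 stays within the scatter of compound 1 and of compound 3. Nothing available gives a cause for this separation.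

Open, on these data alone, is whether the ring nitrogen of the (piperidin-4-yl)oxy group matters for the separation from compound 4, which a open-chain amine such as 2-(dimethylamino)ethoxy, or a carboxylic acid on a short chain, at the same place would help to test. Also open is whether bromo stands for halogens in general at this carbon, which chloro or fluoro there would address, and how any of these compounds behave at concentrations other than the single one tested.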